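A basic side chain replaces tert-butyl on the amide

The source may hold more compounds than are shown below. What is called first, only, known or untested is meant among the compounds shown, and "the series" means these compounds.

Compound 1 `CNC(=O)Nc1ccc2c(c1)nc(SCc1cc([N+](=O)[O-])ccc1OC)n2C(C)C`: > 10000 nM, a limit of the assay.
Compound 2 `CCCn1c(SCc2cc([N+](=O)[O-])ccc2OC)nc2cc(NC(=O)NC(C)(C)C)cc(C(=O)NC(C)(C)C)c21`: 490 nM.

In an assay on isolated protein for inhibition of Gonadotropin-releasing hormone receptor (Rattus norvegicus) (on this read-out lower numbers stand for stronger inhibition and higher numbers for weaker inhibition), compound 2 gives 490 nM, the only true number shown. The other value shown is the limit of > 10000 nM in this assay, at which 1 of the 2 values shown sits. Compound 3 `CCCn1c(SCc2cc([N+](=O)[O-])ccc2OC)nc2cc(NC(=O)NC(C)(C)C)cc(C(=O)NCCCN(C)C)c21` has not yet been measured; it differs from compound 2 by 3-(dimethylamino)propyl in place of tert-butyl on an amide-type nitrogen. Within the data shown here, no measured pair shows a change of this kind, so the expected step is a 1.6-fold lower number from compound 2 to compound 3 (0.21 log units; within the scatter), a modest gain that may not exceed the scatter. Compound 3 is therefore estimated at 300 nM, with a range from 60 nM to 1500 nM.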

Compound 3, half-maximal inhibitory concentration: 19 nM
For compound 3 the middle estimate is 16-fold (1.20 log units) above the measured one; the whole stated range lies above it.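

In this assay, the group on the amide-type nitrogen turns out to matter a great deal: 3-(dimethylamino)propyl in place of tert-butyl gives a 26-fold lower number from compound 2 to compound 3 (1.41 log units; beyond the scatter). Compound 2 alone could not show that this position responds so strongly to a change. Nothing measured here explains the size of this step.

As far as these compounds go, it remains open whether the gain comes from the chain's nitrogen or from its length. A plain butyl chain, a shorter 2-(dimethylamino)ethyl chain or a morpholine at the chain end would help separate these.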